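Mirror Image of Compound 2 and Its Expected Permeability

The source may hold more compounds than are shown below. What is called first, only, known or untested is meant among the compounds shown, and "the series" means these compounds.

Among the measured compounds shown here, compound 2 `N#CC[C@]1(n2cc(-c3nc(-c4cn[nH]c4)cn4nccc34)cn2)C[C@H](C#N)C1` is one of three compounds measured in an ADME assay on MDCK-II cells (Canis lupus familiaris) for permeability; on this read-out higher numbers stand for higher permeability and lower numbers for lower permeability. In this assay compound 2 gives 7 10^-6 cm/s, the lowest of the three numbers. Compound 1 `Cn1ccc(-c2cn3nccc3c(-c3cnn([C@]4(CC#N)C[C@@H](C#N)C4)c3)n2)n1` gives 20 10^-6 cm/s, and compound 3 `CCN1CC(CC#N)(n2cc(-c3nc(-c4cnn(C)c4)cn4nccc34)cn2)C1` gives 33 10^-6 cm/s. For the measured compounds named here, the only step between measured compounds that differ in a single place is a 2.9-fold lower number from compound 1 to compound 2 (0.46 log units; beyond the scatter), in which one group replaces another on an aromatic carbon.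

Compound 4 `N#CC[C@]1(n2cc(-c3nc(-c4cn[nH]c4)cn4nccc34)cn2)C[C@@H](C#N)C1` is the compound still to be measured. (the two compounds have the same atoms and bonds and differ only in configuration as drawn: 2 of 2 stereo elements differ (all stereocentres are inverted: mirror images); a stereocentre at a saturated ring carbon is drawn r in compound 2 and s in compound 4; a stereocentre at a saturated ring carbon is drawn r in compound 2 and s in compound 4). Going by the values given here, none of the measured steps concerns a change in configuration alone; the step from compound 1 to compound 2 is a swap of a group and does not bear on this change. Nothing is added or removed, so no step beyond the scatter is expected, and the step from compound 2 to compound 4 is estimated as no change at the digits printed from compound 2 to compound 4 (within the scatter). Compound 4 is therefore expected to give about 7 10^-6 cm/s, with a range from 3.5 10^-6 cm/s to 14 10^-6 cm/s.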

Compound 4, apparent permeability in the MDCK-II assay: 6 10^-6 cm/s
The estimate for compound 4 lay 1.2-fold (0.07 log units) above the measured number, and the stated range covers the measured number.
By their numbers in the MDCK-II assay, from the lowest: compounds 4 and 2 (each within the scatter of the next); then compounds 1 and 3 (each within the scatter of the next).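

Inverting both stereocentres of compound 2 leaves the picture in the MDCK-II assay unchanged, with a 1.2-fold lower number from compound 2 to compound 4 (0.07 log units; within the scatter), so this pair gives the first direct look at a change in configuration alone, and at these saturated ring carbons it produces no step beyond the scatter. In a physicochemical assay for lipophilicity, using the shake flask method, in phosphate buffer, measured as octanol-water partition, at pH 7.4 (on this read-out higher numbers stand for higher lipophilicity and lower numbers for lower lipophilicity), compound 2 gives 1.7 and compound 4 gives 1.6, which is a number 0.10 log units lower from compound 2 to compound 4 (within the scatter), so this read-out does not separate the pair either. The comparison is a clean one because only one thing varies: the fact that compounds 2 and 4 differ only in the configuration as drawn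

On these data alone, whether the mirror image of compound 1, which carries 1-methyl-1H-pyrazol-3-yl, would stay as level with compound 1 remains open, since this is a single pair. Also open, as far as these compounds go, is how these read-outs would respond to a carboxylic acid in place of either nitrile.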